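The source may hold more compounds than are shown below. What is called first, only, known or untested is meant among the compounds shown, and "the series" means these compounds.

Measured so far:
- compound 1 `Cc1cc(O)cc(-c2nn(CC#N)cc2-c2ccnc(-c3ccc(Oc4ccccc4)cc3)c2)c1`: -12%
- compound 2 `COc1cc(C)cc(-c2nn(CC#N)cc2-c2ccnc(-c3ccc(N(C)C)cc3)c2)c1`: 8%

In a functional assay on SR cells (Homo sapiens) for cytotoxicity, read by sulforhodamine B assay, with a stated time of 48 h, tested at 10 uM (on this read-out higher numbers stand for a weaker effect at the one concentration tested and lower numbers for a stronger effect), compound 2 gives the higher of the two numbers, and compound 1 gives a number lower by an amount beyond the scatter. Compound 3 `Cc1cc(O)cc(-c2nn(CC#N)cc2-c2ccnc(-c3ccc(N(C)C)cc3)c2)c1` remains to be measured. The change from compound 2 to compound 3 is hydrogen in place of methyl on an oxygen on an aromatic ring. Going by the values given here, no measured pair covers this change on its own, so the step of a number 8 percentage points lower from compound 2 to compound 3 (within the scatter) is expected to be small, downward if anything, and not clearly beyond the scatter. For compound 3 a value of 0% is estimated, within -20% to 18%.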

Compound 3, a percentage reported as activity, at one concentration (the size of the read-out at that concentration, not a potency): 4%
Compound 3: middle estimate off by 4 percentage points, on the low side, and the stated range covers the measured number.
By their numbers in this assay, from the lowest: compound 1; then compounds 3 and 2 (each within the scatter of the next).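

In this assay the methoxy to hydroxy change on the 3-methoxy-5-methylphenyl group can now be read on its own, and a number 4 percentage points lower from compound 2 to compound 3 (within the scatter) shows that the oxygen's methyl can be replaced by hydrogen without a change beyond the scatter. Dimethylamino in place of phenoxy on an aromatic carbon gives a number 16 percentage points higher from compound 1 to compound 3 (beyond the scatter) and so a weaker effect at the one concentration tested. No measurement at hand explains either step.

Open, as far as these compounds go, is whether an amine or an ethoxy group on that ring would behave like hydroxy. Also open, from the compounds shown here alone, is whether the phenoxy to dimethylamino step holds with methoxy in place of hydroxy.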